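Swapping a hexyl chain for a dimethoxyphenyl ring

The compounds below may be only part of what the source reports. "The series", "measured", "known", "first", "only" and "open" are said of these compounds alone.

Measured so far:
Compound 1 `CCCCCCNc1nc(SCc2ccc(C(F)(F)F)cc2)nc2ccccc12`: 20200 nM
Compound 2 `FC(F)(F)c1ccc(CSc2nc(Nc3cccc(Cl)c3)c3ccccc3n2)cc1`: 18000 nM
Compound 3 `FC(F)(F)c1ccc(CSc2nc(Nc3ccc(Cl)cc3)c3ccccc3n2)cc1`: 15100 nM

All three share one core and were tested in a functional assay on MDA-MB-231 cells (Homo sapiens) for cytotoxicity, read by MTT assay, with a stated time of 72 h; on this read-out higher numbers stand for weaker inhibition and lower numbers for stronger inhibition. Compound 1 has the highest of the three numbers, although the steps from it to the other two both stay within the scatter of the assay. Replacing its hexyl with a 3-chlorophenyl gives a 1.1-fold lower number from compound 1 to compound 2 (0.05 log units; within the scatter), and with a 4-chlorophenyl gives a 1.3-fold lower number from compound 1 to compound 3 (0.13 log units; within the scatter); between the two chlorophenyl compounds the step is a 1.2-fold lower number from compound 2 to compound 3 (0.08 log units; within the scatter). In short, exchanging the hexyl chain on this nitrogen for an aromatic ring has so far left the read-out essentially unchanged.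

Compound 4 `COc1ccc(Nc2nc(SCc3ccc(C(F)(F)F)cc3)nc3ccccc23)cc1OC` takes the same step in a different direction: 3,4-dimethoxyphenyl in place of hexyl on a nitrogen on an aromatic ring. Going by the values given here, the only comparable steps, from compound 1 to compound 2 and to compound 3, were within the scatter, and nothing among the measured compounds points to a larger effect for the two methoxy groups. For compound 4 the expected step is therefore a 1.2-fold lower number from compound 1 to compound 4 (0.07 log units; within the scatter), no movement beyond the scatter. The estimate for compound 4 in this assay is 17000 nM, with a range from 7000 nM to 40000 nM.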

Compound 4, half-maximal inhibitory concentration: 18900 nM
Compound 4: middle estimate off by 1.1-fold (0.05 log units), on the low side, and the stated range covers the measured number.
By their numbers in this assay, from the lowest: compounds 3, 2, 4 and 1 (each within the scatter of the next).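

In this assay, 3,4-dimethoxyphenyl in place of hexyl gives a 1.1-fold lower number from compound 1 to compound 4 (0.03 log units; within the scatter), while the same group in place of 3-chlorophenyl gives a 1.1-fold higher number from compound 2 to compound 4 (0.02 log units; within the scatter), and in place of 4-chlorophenyl gives a 1.3-fold higher number from compound 3 to compound 4 (0.10 log units; within the scatter). The earlier compounds shown here had tested only chlorine-bearing rings against the hexyl chain; this result extends the flat picture to a larger ring with oxygen-containing methoxy groups, so all four groups on this nitrogen remain within the scatter of one another. No measurement is available that would explain this lack of movement.

Still open, going by these compounds, is whether any group on this nitrogen can move the number beyond the scatter, such as a methyl group, a piperidine ring or a phenyl ring carrying a carboxylic acid. All four compounds also share everything outside this one position, so they say nothing about how changes elsewhere on the shared core, such as replacing the trifluoromethyl group with a nitrile, would affect the read-out.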